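A Fluorine Added to Compound 1

The source may report more compounds than this note shows. Statements on the series, on what has been measured and on what is new or still open speak of the compounds shown alone.

Measured so far:
- compound 1, `O=C(/C=C\Nc1ccc(C(F)(F)F)cc1)c1cn(-c2ccccc2)nc1-c1ccccc1`, with > 50000 nM (a limit)
- compound 2, `COc1ccc(N/C=C\C(=O)c2cn(-c3ccccc3)nc2-c2ccccc2)cc1`, with > 50000 nM (a limit)

In an ADME assay on HaCaT cells (Homo sapiens) for antiproliferative activity, read by MTT assay, with a stated time of 48 h (a lower number here means a stronger inhibitor, a higher number a weaker inhibitor), compound 1 gives > 50000 nM, which is a limit of the assay and not a number. Compound 2 gives > 50000 nM, also a limit. Going by the values given here, the one measured step, a step that the two limits leave unreadable from compound 1 to compound 2, therefore cannot be sized. Compound 3, `O=C(/C=C\Nc1ccc(C(F)(F)F)cc1)c1cn(-c2ccccc2)nc1-c1ccc(F)cc1`, differs from compound 1 by fluoro in place of hydrogen on an aromatic carbon. Among the compounds with values here, no measured step covers such a change, and the limit of > 50000 nM in this assay, at which 2 of the 2 values shown sit, leaves compound 1 without a number to move from. Compound 3 is therefore expected to remain at that limit, with an estimated step that the limit leaves unreadable from compound 1 to compound 3. For compound 3 the estimate is 80000 nM, expected to lie between 20000 nM and 300000 nM.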

Compound 3, half-maximal inhibitory concentration: > 50000 nM
Compound 3: only a limit was reported; the forecaster's own chance of this, stated with the estimate: 85%; the middle value is on the limit's open side.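

No step can be read from compound 1 to compound 3, because both results are limits and not numbers: the limit of > 50000 nM in this assay, at which 3 of the 3 values shown sit.

From the compounds shown here alone, whether fluoro in place of hydrogen changes activity at all in this assay stays open.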